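Allyl in place of methyl at the ring amine of compound 3

The source may report more compounds than this note shows. Statements on the series, on what has been measured and on what is new or still open speak of the compounds shown alone.

The study gathers three measured compounds and one awaiting measurement. In a functional assay (brain) for displacement of a labelled ligand, with Rattus norvegicus as the target (on this read-out lower numbers stand for stronger inhibition and higher numbers for weaker inhibition), compound 1 `CC(C)[C@]1(c2ccccc2)OC[C@H]([C@@H]2CCCCN2)O1` gives 45 nM, compound 2 `CC[C@]1(c2cccs2)OC[C@H]([C@@H]2CCCCN2)O1` gives 205 nM, and compound 3 `CN1CCCC[C@H]1[C@H]1COC(c2ccccc2)(c2ccccc2)O1` gives 4400 nM. Compound 3 thus shows the highest number of the three; its nearest neighbour is compound 2, and both gaps to the other compounds lie beyond the usual scatter, so compound 3 is the weakest inhibitor of the set as measured in this assay.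

Compound 4 `C=CCN1CCCC[C@H]1[C@H]1COC(c2ccccc2)(c2ccccc2)O1` differs from compound 3 in one place: vinyl in place of hydrogen on a saturated chain carbon bound to an amine nitrogen in a ring. Within the data shown here, no measured pair in the set carries this change, so nothing in the numbers themselves shows its size or direction. The account therefore expects the step from compound 3 to compound 4 to be small, with either direction possible, as a 1.1-fold higher number from compound 3 to compound 4 (0.06 log units; within the scatter) expresses. On that basis compound 4 is estimated to give about 5000 nM in this assay, within a range from 1500 nM to 16000 nM.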

Compound 4, inhibition constant: 15200 nM
Beside the measured number, compound 4's estimate is 3.0-fold (0.48 log units) below it; the measured number falls inside the stated range.
By their numbers in this assay, from the lowest: compound 1; then compound 2; then compound 3; then compound 4.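

Among these compounds, the first measured step between compounds that differ in one place shows that this position responds to substitution: vinyl in place of hydrogen on a saturated chain carbon bound to an amine nitrogen in a ring brings a 3.5-fold higher number from compound 3 to compound 4 (0.54 log units; beyond the scatter) in this assay. The step is modest but beyond the scatter, and it runs towards weaker inhibition. Going from methyl to allyl therefore weakens inhibition further, starting from the compound that had the highest number among the earlier three.

As far as these compounds go, whether an ethyl chain, a saturated propyl chain or a benzyl group at the same place would move the number in the same direction stays open, as does whether the step would carry over to the cores of compound 1 and compound 2. Nothing given here accounts for the size or direction of this step.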